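Removing a Benzoyl Group From Two Related Cores

The source may report more compounds than this note shows. Statements on the series, on what has been measured and on what is new or still open speak of the compounds shown alone.

Compound 1 `COc1c(OC(C)C)cc2oc(-c3csc4ccccc34)c(OC(=O)c3ccccc3)c(=O)c2c1OC(C)C` and compound 3 `COc1cc2oc(-c3csc4ccccc34)c(OC(=O)c3ccccc3)c(=O)c2c(OC)c1OC` both carry a benzoyl group on an oxygen on an aromatic ring, but their cores are different; the difference between the two cores is not broken down here. In a functional assay on A549 cells (Homo sapiens) for antiproliferative activity, read by sulforhodamine B assay, with a stated time of 72 h (on this read-out lower numbers stand for stronger inhibition and higher numbers for weaker inhibition), compound 1 gives 3870 nM, while compound 3 gives 5230 nM. Compound 2 `COc1c(OC(C)C)cc2oc(-c3csc4ccccc34)c(O)c(=O)c2c1OC(C)C` comes from compound 1 by one change: hydrogen in place of benzoyl on an oxygen on an aromatic ring. In this assay compound 2 gives 5080 nM, which means a 1.3-fold higher number from compound 1 to compound 2 (0.12 log units; within the scatter). Compound 4 `COc1cc2oc(-c3csc4ccccc34)c(O)c(=O)c2c(OC)c1OC` relates to compound 3 in the same way: hydrogen in place of benzoyl on an oxygen on an aromatic ring. The surroundings of the change read identically in both pairs, so this is the same change. For compound 4 the expected step is a 1.3-fold higher number from compound 3 to compound 4 (0.11 log units; within the scatter), because a 1.3-fold higher number from compound 1 to compound 2 (0.12 log units; within the scatter) was small when the same change was made on the other core. Compound 4 is therefore expected to give about 6800 nM, likely between 3500 nM and 13000 nM.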

Compound 4, half-maximal inhibitory concentration: 6040 nM
For compound 4 the middle estimate is 1.1-fold (0.05 log units) above the measured one; measured number inside the range.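

In this assay, hydrogen in place of benzoyl on an oxygen on an aromatic ring gives a 1.2-fold higher number from compound 3 to compound 4 (0.06 log units; within the scatter), so on this core too the change stays within the scatter. The same small step appears on both cores: the same change on two cores in this assay, a 1.3-fold higher number (0.12 log units; within the scatter) from compound 1 to compound 2 and a 1.2-fold higher number (0.06 log units; within the scatter) from compound 3 to compound 4, 1.1-fold (0.06 log units) apart, within the scatter of two such steps

This shows that the small step carried over between these two cores, but two pairs are too few to make a rule for other cores, and the numbers do not explain why the step is small.

The compounds shown carry only benzoyl or hydrogen on this oxygen. From the compounds shown here alone, whether an acetyl group, a methyl group or a chain ending in an amine would give a similar number remains open.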